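The compounds below may be only part of what the source reports. "The series", "measured", "known", "first", "only" and "open" are said of these compounds alone.

Compound 1, `Fc1ccccc1Nc1nc2nonc2nc1Nc1cccc(F)c1F`, is the starting point. In an assay on mitochondria from L6 cells (Rattus norvegicus) for activation, with a stated time of 90 min (a lower number here means that less compound is needed, a higher number that more compound is needed for the effect), compound 1 gives 500 nM. Its closest neighbour among the plain numbers is compound 2, `Fc1ccccc1Nc1nc2nonc2nc1Nc1cccc(OC(F)(F)F)c1`, which gives 600 nM in this assay; the two values lie within the usual scatter of each other, so neither can be called stronger. Compound 3, `Fc1ccccc1Nc1nc2nonc2nc1Nc1cccc(C(F)(F)F)c1F`, gives in this assay only a limit, < 370 nM, rather than a number. For the measured compounds named here, the one step measured so far, an at least 1.3-fold lower number from compound 1 to compound 3 (0.13 log units; that floor lies within the scatter), is therefore bounded by the limit of < 370 nM in this assay, at which 1 of the 3 values shown sits, and does not by itself establish a change beyond the scatter.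

Compound 4, `Oc1ccc(F)c(Nc2nc3nonc3nc2Nc2ccccc2F)c1`, has not yet been measured. It differs from compound 1 in one place: 2-fluoro-5-hydroxyphenyl in place of 2,3-difluorophenyl on a nitrogen on an aromatic ring. Going by the values given here, no measured step touches a hydroxyl group, and the only measured step concerns a trifluoromethyl in place of fluoro, which bears on compound 4 only indirectly. There is thus no measured evidence for a move in either direction, and the expectation is a step about the size of the scatter, no change at the digits printed from compound 1 to compound 4 (within the scatter). For compound 4 the estimated value in this assay is 500 nM, expected to fall between 200 nM and 1500 nM.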

Compound 4, half-maximal effective concentration: 30000 nM
For compound 4 the middle estimate is 60-fold (1.78 log units) below the measured one, and the stated range ends below it.
By their numbers in this assay, from the lowest: compounds 1 and 2 (each within the scatter of the next); then compound 4. At a limit, below all of these: compound 3.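

The group on a nitrogen on an aromatic ring turns out to be far from free to change: putting 2-fluoro-5-hydroxyphenyl in place of 2,3-difluorophenyl gives a 60-fold higher number from compound 1 to compound 4 (1.78 log units; beyond the scatter) in this assay, so much more compound is needed for the effect. For the compounds shown here, the earlier groups at this place all carried fluorine, and none showed a step beyond the scatter, so compound 4 is the first to show how much this place can matter. The entering group counts a hydrogen-bond donor and a hydrogen-bond acceptor that the leaving group lacks, but this is only a count, and nothing measured here explains the rise.

This single change removes a fluoro group and adds a hydroxyl at once, so the compounds shown cannot separate the two effects, which a plain 2-fluorophenyl group could begin to do. They also leave open whether a methoxy group, an amine or a carboxylic acid in place of the hydroxyl would raise the number as sharply, or would stay close to compound 1.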